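Adding a Third Fluorine to the Benzyl Group

This account rests on a few compounds, and the source may have more. Where it says the series, first, only, none or still open, it means among the compounds named here.

The shared core of compound 1 `COc1ccc2[nH]c3c(c2c1)CCNC31CCN(Cc2cc(F)cc(Cl)c2)CC1` was tested in an assay on FRT cells for positive allosteric modulation of Cystic fibrosis transmembrane conductance regulator variant N1303K (Homo sapiens), in the presence of a further agent that is not named here (on this read-out lower numbers stand for an effect already at smaller amounts and higher numbers for an effect only at larger amounts of compound), and gives 2500 nM. Compound 2 `COc1ccc2[nH]c3c(c2c1)CCNC31CCN(Cc2ccccc2Cl)CC1` gives 2200 nM in the same assay, and compound 3 `COc1ccc2[nH]c3c(c2c1)CCNC31CCN(Cc2ccc(F)cc2F)CC1` gives 2000 nM. The steps between these three, a 1.1-fold lower number from compound 1 to compound 2 (0.06 log units; within the scatter), a 1.3-fold lower number from compound 1 to compound 3 (0.10 log units; within the scatter) and a 1.1-fold lower number from compound 2 to compound 3 (0.04 log units; within the scatter), all lie within the scatter, so the benzyl substitution pattern has so far not moved the read-out. Compound 4 `COc1ccc2[nH]c3c(c2c1)CCNC31CCN(Cc2ccc(F)c(F)c2F)CC1` differs from compound 3 by fluoro in place of hydrogen on an aromatic carbon. Since every exchange of halogen pattern on this ring was without effect beyond the scatter, no step beyond the scatter is expected here either. The expected step is no change at the digits printed from compound 3 to compound 4 (within the scatter). Compound 4 is therefore expected to give 2000 nM, with a range from 1000 nM to 4000 nM.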

Compound 4, half-maximal effective concentration: 4100 nM
For compound 4 the middle estimate is 2.1-fold (0.31 log units) below the measured one; the whole stated range lies below it.
By their numbers in this assay, from the lowest: compounds 3, 2, 1 and 4 (each within the scatter of the next, the first and the last beyond it).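

Fluoro on this aromatic carbon, ortho to two fluoro groups, is the first change on the benzyl ring to shift the number in this assay beyond the scatter (a 2.1-fold higher number from compound 3 to compound 4 (0.31 log units; beyond the scatter)). The shift is modest and appears only against compound 3, as the 2,3,4-trifluorophenyl group stays within the scatter of the other two benzyl patterns (a 1.9-fold higher number from compound 2 to compound 4 (0.27 log units; within the scatter); a 1.6-fold higher number from compound 1 to compound 4 (0.21 log units; within the scatter)). Nothing available accounts for this step. Still open, on these data alone, is whether chloro, methyl or methoxy on this same carbon would give a similar step.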